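The source may hold more compounds than are shown below. What is called first, only, known or untested is meant among the compounds shown, and "the series" means these compounds.

Measured so far: compound 1 `Cc1nn(C)c(Oc2cccc(F)c2)c1/C=N\CCCCCOc1cc2oc(=O)cc(C)c2cc1Cl`, compound 2 `Cc1nn(C)c(Oc2cccc(F)c2)c1/C=N\CCCCCCOc1cc2oc(=O)cc(C)c2cc1Cl`, compound 3 `Cc1nn(C)c(Oc2ccc(F)cc2F)c1/C=N\CCCCCCOc1cc2oc(=O)cc(C)c2cc1Cl`.

In a functional assay on U-87MG ATCC cells for antiproliferative activity against U-87 MG (Homo sapiens), read by MTT assay, with a stated time of 72 h (on this read-out lower numbers stand for stronger inhibition and higher numbers for weaker inhibition), compound 1 gives 9870 nM. Compound 2 returns only a limit in this assay, > 25000 nM. Compound 3 likewise returns only a limit in this assay, > 25000 nM. Among the measured compounds shown here, compound 3 therefore stands at the upper end of what this assay resolves, with no number of its own; the same holds for compound 2, and the one measured step, a step that the two limits leave unreadable from compound 2 to compound 3, is a step between two limits and cannot be read. For the measured compounds named here, compound 1 is the only member with a number, and it differs from compound 2 in the chain; no step is given for that pair, so only the two values themselves are noted.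

Compound 4 `Cc1nn(C)c(Oc2cccc(Br)c2)c1/C=N\CCCCCCOc1cc2oc(=O)cc(C)c2cc1Cl` is not yet measured. The change from compound 3 is 3-bromophenyl in place of 2,4-difluorophenyl on an oxygen on an aromatic ring. Going by the values given here, no measured step concerns a bromine on this phenyl ring, and the only step at this position, a step that the two limits leave unreadable from compound 2 to compound 3, carries no size. What is shared with compound 2 and compound 3 is the six-carbon chain, and both of those sit at the limit of > 25000 nM in this assay, at which 2 of the 3 values shown sit. Compound 4 is therefore expected to sit in the same region, and the step that the limit leaves unreadable from compound 3 to compound 4 is expected to be no larger than the scatter. For compound 4 the estimate in this assay is 30000 nM, between 10000 nM and 90000 nM, most likely reported again as a limit.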

Compound 4, half-maximal inhibitory concentration: 3610 nM
The estimate for compound 4 lay 8.3-fold (0.92 log units) above the measured number; measured number below the stated range.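

Among the compounds shown here, at the place on an oxygen on an aromatic ring, the aryl group can shift the read-out in this assay: 3-bromophenyl in place of 2,4-difluorophenyl gives an at least 6.9-fold lower number from compound 3 to compound 4 (0.84 log units; beyond the scatter), and compound 4 is the first member with this chain to return a number. The cleaner comparison, bromo in place of fluoro on an aromatic carbon, gives an at least 6.9-fold lower number from compound 2 to compound 4 (0.84 log units; beyond the scatter), so the change of halogen alone is enough to bring the compound into the measurable range, and both steps are minimum sizes only. The step between the two difluoro and monofluoro compounds cannot be read, so nothing can be said about the second fluorine, and the floor of the comparison is set by the assay limit: the limit of > 25000 nM in this assay, at which 2 of the 4 values shown sit.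

The compounds shown leave open whether bromo would have the same effect on the chain of compound 1, which gives 9870 nM in this assay, since no compound pairs bromo with that chain. They also leave open whether the gain is specific to bromine or would extend to chloro, iodo, methyl or trifluoromethyl on the same phenyl ring.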